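This account rests on a few compounds, and the source may have more. Where it says the series, first, only, none or still open, it means among the compounds named here.

Measured compounds:
Compound 1 `CCCCCCOc1ccc2c(Cl)ccnc2c1` gives 2720 nM in a functional assay on RKO cells (Homo sapiens) for cytotoxicity, read by MTT assay, with a stated time of 48 h; on this read-out higher numbers stand for weaker inhibition and lower numbers for stronger inhibition.
Compound 2 `CCOc1ccc2c(Cl)ccnc2c1` gives 3870 nM in this assay.
Compound 3 `Clc1ccnc2cc(OCCCc3ccccc3)ccc12` gives 1420 nM in this assay.

Compound 1 holds the second highest of the three numbers. Its nearest neighbour is compound 2, a 1.4-fold higher number from compound 1 to compound 2 (0.15 log units; within the scatter), within the scatter; the further one is compound 3, a 1.9-fold lower number from compound 1 to compound 3 (0.28 log units; within the scatter), also within the scatter. Within the data shown here, the one step beyond the scatter is a 2.7-fold lower number from compound 2 to compound 3 (0.44 log units; beyond the scatter), and it, like the other two, changes only the chain on the oxygen on the aromatic ring while the chloro is kept.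

Compound 4 `CCCCCCOc1ccc2c(NCCN(C)C)ccnc2c1` differs from compound 1 at the core instead: (2-(dimethylamino)ethyl)amino in place of chloro on an aromatic carbon. Among the measured compounds shown here, none of the measured steps touches this position; all three vary the chain. For the measured compounds named here, there is therefore no measured step that bears on the change from compound 1 to compound 4, and nothing sets its direction or size in this assay. The working expectation is no step beyond the scatter, with a range widened to reflect the absence of any bearing data. Compound 4 is expected at 2500 nM, with a range from 500 nM to 12000 nM. This amounts to an expected step of a 1.1-fold lower number from compound 1 to compound 4 (0.04 log units; within the scatter).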

Compound 4, half-maximal inhibitory concentration: 1120 nM
Estimate against measurement, compound 4: 2.2-fold (0.35 log units) above, and the stated range covers the measured number.
By their numbers in this assay, from the lowest: compounds 4, 3, 1 and 2 (each within the scatter of the next, the first and the last beyond it).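

In this assay, the position opposite the ring nitrogen responds to substitution: with the chain on the oxygen kept, (2-(dimethylamino)ethyl)amino in place of chloro gives a 2.4-fold lower number from compound 1 to compound 4 (0.39 log units; beyond the scatter) as a modest step, and it is the only step shown at this position. Chloro is therefore not needed for activity on this read-out, and a group of 6 heavy atoms, carrying a hydrogen-bond donor and hydrogen-bond acceptors that chloro lacks, is accepted on this aromatic carbon with a lower number rather than a loss. No measurement shown accounts for the size or direction of this step.

From the compounds shown here alone, the result rests on a single pair, so it remains open whether the same replacement gives a similar step with the ethyl or 3-phenylpropyl chain on the oxygen. Going by these compounds, it also remains open which part of the new group matters, a question that a plain amino group, a (2-hydroxyethyl)amino group or a (3-(dimethylamino)propyl)amino group at this position could address.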